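Removing the chloro group from compound 2

The compounds below may be only part of what the source reports. "The series", "measured", "known", "first", "only" and "open" are said of these compounds alone.

In a functional assay on SW480 cells (Homo sapiens) for cytotoxicity, read by MTT assay, with a stated time of 48 h (on this read-out higher numbers stand for weaker inhibition and lower numbers for stronger inhibition), compound 1 (`COc1cc([C@@H]2C[C@@]2(CO)C(=O)Nc2ccccc2)cc(OC)c1OC`) gives 76800 nM and compound 2 (`CCOC(=O)[C@@]1(C(=O)Nc2ccccc2Cl)C[C@H]1c1cc(OC)c(OC)c(OC)c1`) gives 30100 nM. Compound 2 holds the lower of the two numbers, by a gap beyond the usual scatter. Compound 3 (`CCOC(=O)[C@@]1(C(=O)Nc2ccccc2)C[C@H]1c1cc(OC)c(OC)c(OC)c1`) departs from compound 2 by hydrogen in place of chloro on an aromatic carbon, so that 2-chlorophenyl becomes phenyl. Among the measured compounds shown here, no step between measured compounds isolates this change, which leaves the expectation weakly supported. It starts from compound 2 at 30100 nM, and a small move toward a higher number in this assay is expected, probably not clearly beyond the scatter. The estimated change is a 1.6-fold higher number from compound 2 to compound 3 (0.20 log units; within the scatter). For compound 3 the expected value is 48000 nM, with an estimated range of 20000 nM to 100000 nM.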

Compound 3, half-maximal inhibitory concentration: > 100000 nM
Compound 3 ended at the assay's limit; the forecaster's own chance of this, stated with the estimate: 15%; middle value at least 2.0-fold (0.31 log units) away from the limit.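

As far as these compounds go, compound 3 sits at a limit of this assay, not at a number: the limit of > 100000 nM in this assay, at which 1 of the 3 values shown sits. The chloro group on the aromatic carbon ortho to a large group now has a step of its own: an at least 3.3-fold higher number from compound 2 to compound 3 (0.52 log units; beyond the scatter), so with ethoxycarbonyl held fixed, 2-chlorophenyl gives the stronger inhibition of the pair, and the true size of the step remains unknown. With phenylcarbamoyl held fixed, ethoxycarbonyl in place of hydroxymethyl gives an at least 1.3-fold higher number from compound 1 to compound 3 (0.11 log units; that floor lies within the scatter), a floor within the scatter that settles neither the size nor the direction of this change.

The compounds shown leave open whether the effect is specific to chloro or would also appear with a fluoro, methyl or methoxy group at that place. Also open, from the compounds shown here alone, is whether a carboxylic acid or a primary amide would behave differently from ethoxycarbonyl and hydroxymethyl on the saturated ring carbon.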